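The compounds below may be only part of what the source reports. "The series", "measured", "known", "first", "only" and "open" are said of these compounds alone.

Compound 1 `CC(C)(C)OC(=O)CCC(Nc1ccc(CN(CCCc2c(N)nc(N)nc2O)c2cc(F)c([N+](=O)[O-])cc2[N+](=O)[O-])cc1)C(=O)OC(C)(C)C`: 2600 nM
Compound 2 `Nc1nc(N)c(CCCN(Cc2ccc(NC(CCC(=O)O)C(=O)O)cc2)c2cc(F)c(F)cc2[N+](=O)[O-])c(O)n1`: > 100000 nM (a limit of the assay, not a number)

Among the measured compounds shown here, in a functional assay on CCRF-CEM cells (Homo sapiens) for cytotoxicity, in the absence of a further agent (a lower number here means a stronger inhibitor, a higher number a weaker inhibitor), compound 1 gives 2600 nM, the only actual number so far. The one other result is the limit for compound 2. Compound 3 `CC(C)(C)OC(=O)CCC(Nc1ccc(CN(CCCc2c(N)nc(N)nc2O)c2cc(F)ccc2[N+](=O)[O-])cc1)C(=O)OC(C)(C)C` comes from compound 1 by a single change, hydrogen in place of nitro on an aromatic carbon, ortho to a fluoro group and meta to a nitro group. For the measured compounds named here, no measured pair tests this change, so the expectation is tentative. A moderate loss of potency is expected, an estimated step of a 2.3-fold higher number from compound 1 to compound 3 (0.36 log units; beyond the scatter) in this assay. Compound 3 is estimated at 6000 nM, with an expected range of 1500 nM to 30000 nM.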

Compound 3, half-maximal inhibitory concentration: 3400 nM
The estimate for compound 3 lay 1.8-fold (0.25 log units) above the measured number; the measured number falls inside the stated range.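

In this assay, among the compounds shown here, hydrogen in place of nitro gives a 1.3-fold higher number from compound 1 to compound 3 (0.12 log units; within the scatter), the first reading at this position, on the aromatic carbon ortho to a fluoro group and meta to a nitro group. The nitro group here can therefore give way to hydrogen with no difference that stands clear of the scatter. Nothing in the data shown gives a cause for this. As far as these compounds go, it stays open whether an amine, a methoxy group or a carboxylic acid at the same carbon would read alike, and whether the other nitro group, meta to this position, can be exchanged in the same way.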